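Swapping Selenium for Sulfur on Compound 1

This account rests on a few compounds, and the source may have more. Where it says the series, first, only, none or still open, it means among the compounds named here.

Compound 1, with the structure `C[Se]/C(=N\C(=O)c1cc2ccccc2s1)NC(=O)c1cc2ccccc2s1`, was tested in a functional assay on K562 cells (Homo sapiens) for cytotoxicity, read by MTT assay, with a stated time of 72 h (a higher number here means a weaker inhibitor of growth, a lower number a stronger inhibitor of growth), where it gives 32400 nM. Two related compounds that carry a methylsulfanyl group in place of the selenium-bearing group were measured in the same way. Compound 2, `CS/C(=N\C(=O)c1sccc1Cl)NC(=O)c1sccc1Cl`, gives 37000 nM in this assay, a number that lies within the usual scatter of the value of compound 1, so the two cannot be told apart. Compound 3, `CS/C(=N\C(=O)c1ccno1)NC(=O)c1ccno1`, reaches only a limit of the assay, > 100000 nM, and no number is known for it; that is the limit of > 100000 nM in this assay, at which 1 of the 3 values shown sits.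

Compound 4, `CS/C(=N\C(=O)c1cc2ccccc2s1)NC(=O)c1cc2ccccc2s1`, has not yet been measured. It differs from compound 1 by a group of 2 heavy atoms (1 carbon, 1 sulfur; no ring) in place of a group of 2 heavy atoms (1 carbon, 1 selenium; no ring), on a carbon with a double bond to nitrogen. Among the measured compounds shown here, no measured pair here shows such a swap on an otherwise unchanged compound, so the size of the step can only be guessed. A modest move toward a weaker inhibitor of growth, near the edge of the scatter, is expected, a 1.7-fold higher number from compound 1 to compound 4 (0.23 log units; within the scatter). Compound 4 is therefore estimated to give about 55000 nM in this assay, with an expected range from 20000 nM to 150000 nM.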

Compound 4, concentration for 50% growth inhibition: 34700 nM
Compound 4: middle estimate off by 1.6-fold (0.20 log units), on the high side; measured number inside the range.
By their numbers in this assay, from the lowest: compounds 1, 4 and 2 (each within the scatter of the next). At a limit, above all of these: compound 3.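

Among the compounds shown here, this is the first direct reading of the swap on a carbon with a double bond to nitrogen, with the rest of the compound left unchanged. In this assay, methylsulfanyl in place of the selenium-bearing group gives a 1.1-fold higher number from compound 1 to compound 4 (0.03 log units; within the scatter), so compound 1 and compound 4 cannot be told apart, and on this core sulfur can stand where selenium stood with no change beyond the scatter. Nothing measured here offers a reason for this outcome.

The compounds shown leave open whether the same swap would read alike on the other cores, those of compound 2 and compound 3. They also leave open how this carbon would respond to a quite different group, such as an amine or a longer sulfur-bearing chain like ethylsulfanyl.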